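A Pyrimidine Ring in Place of the Methoxyphenyl

A few compounds are considered here, and "the series" means these few. Any claim that something is new, unique, unknown or untested is made for them only; others in the source may bear on it.

Compound 1, `O=C(CCCCCCc1nc2ccc(-c3ccccc3)cc2[nH]1)NO`: 100 nM
Compound 2, `O=C(CCCCCCc1nc2ccc(-c3ccc(F)cc3)cc2[nH]1)NO`: 1200 nM
Compound 3, `COc1ccc(-c2ccc3nc(CCCCCCC(=O)NO)[nH]c3c2)cc1`: 3100 nM

All three were measured in a functional assay on SK-OV-3 cells (Homo sapiens) for cytotoxicity; a lower number here means a stronger inhibitor, a higher number a weaker inhibitor. Compound 3 stands highest of the three: a 31-fold higher number from compound 1 to compound 3 (1.49 log units; beyond the scatter) and a 2.6-fold higher number from compound 2 to compound 3 (0.41 log units; beyond the scatter). Compound 4, `O=C(CCCCCCc1nc2ccc(-c3cncnc3)cc2[nH]1)NO`, differs from compound 3 in one place: pyrimidin-5-yl in place of 4-methoxyphenyl on an aromatic carbon. Among the measured compounds shown here, no measured step exchanges one ring for another, so the guide is indirect. Compound 1 carries neither fluoro nor methoxy, and adding either raised the number, a 12-fold higher number from compound 1 to compound 2 (1.08 log units; beyond the scatter) and a 31-fold higher number from compound 1 to compound 3 (1.49 log units; beyond the scatter). Losing the methoxy might therefore move back toward compound 1, but a ring with hetero atoms enters without any precedent here. A modest to large decrease is expected, a 6.2-fold lower number from compound 3 to compound 4 (0.79 log units; beyond the scatter). Compound 4 is estimated at 500 nM, likely between 100 nM and 2500 nM.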

Compound 4, half-maximal inhibitory concentration: 2600 nM
Compound 4: middle estimate off by 5.2-fold (0.72 log units), on the low side, and the stated range ends below it.
By their numbers in this assay, from the lowest: compound 1; then compound 2; then compounds 4 and 3 (each within the scatter of the next).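

In this assay, pyrimidin-5-yl in place of 4-methoxyphenyl changes nothing that can be told from the scatter (a 1.2-fold lower number from compound 3 to compound 4 (0.08 log units; within the scatter)), so removing the methoxy along with the all-carbon ring does not recover the low number of the plain phenyl. Pyrimidin-5-yl also falls behind both 4-fluorophenyl (a 2.2-fold higher number from compound 2 to compound 4 (0.34 log units; beyond the scatter)) and plain phenyl (a 26-fold higher number from compound 1 to compound 4 (1.41 log units; beyond the scatter)), so each of the three replacements of phenyl shown here raises the number. Nothing available explains this result.

Still open, as far as these compounds go, is whether a pyridin-3-yl ring, or a methyl or chloro on the phenyl, would stay close to compound 1 at 100 nM.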